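Cytotoxicity notes: compound 1 and the step to compound 3

The source may report more compounds than this note shows. Statements on the series, on what has been measured and on what is new or still open speak of the compounds shown alone.

Among the compounds with values here, in an ADME assay on MT4 cells (Homo sapiens) for cytotoxicity, read by XTT assay, with a stated time of 5 days (a lower number here means a stronger inhibitor, a higher number a weaker inhibitor), compound 1 (`CC[C@H](C)[C@H](NC(=O)[C@@H](N)CO)C(=O)N[C@@H](C)C(=O)N[C@@H](CCC(=O)O)C(=O)NC12NC(=O)C3(O)C4C5CC(C6C5C3C61)C42`) gives 218000 nM as the only exact number so far. Compound 2 (`CC[C@H](C)[C@H](NC(=O)[C@@H](N)CO)C(=O)N[C@@H](C)C(=O)NC12NC(=O)C3(O)C4C5CC(C6C5C3C61)C42`) carries only a limit (> 300000 nM) in this assay and no number.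

Compound 3 (`CC[C@H](C)[C@H](N)C(=O)N[C@@H](C)C(=O)N[C@@H](CCC(=O)O)C(=O)NC12NC(=O)C3(O)C4C5CC(C6C5C3C61)C42`) is compound 1 with hydrogen in place of (1-amino-2-hydroxyethyl)carbonyl on an amine nitrogen. Within the data shown here, no measured pair isolates this change, so the size of the step is a matter of judgement. In this assay a step no larger than the usual scatter is expected, with a slight lean towards a weaker reading. The starting point for that expectation is compound 1 at 218000 nM. A report of a limit alone for compound 3 is nearly as likely as a number. The expected step of a 1.1-fold higher number from compound 1 to compound 3 (0.06 log units; within the scatter) is an estimate that stays within the scatter. The estimated value for compound 3 is 250000 nM (expected range 120000 nM to 350000 nM).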

Compound 3, half-maximal inhibitory concentration: 216000 nM
Compound 3: middle estimate off by 1.2-fold (0.06 log units), on the high side, within the range that was stated.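

Within the data shown here, compound 1 and compound 3 form the first measured pair that isolates a single change, and in this assay the step is a 1.0-fold lower number from compound 1 to compound 3 (0.00 log units; within the scatter). On this amine nitrogen, then, (1-amino-2-hydroxyethyl)carbonyl and hydrogen give readings that cannot be told apart, so the group, with its defined stereocentre, makes no readable difference to the cytotoxicity read-out in this pair. Compound 2 in this assay remains a limit and not a number, and steps to it cannot be read: the limit of > 300000 nM in this assay, at which 1 of the 3 values shown sits.

On these data alone, whether another group on the same amine nitrogen, such as an acetyl or a longer peptide chain, would move the reading stays open. As far as these compounds go, the pair also speaks only to cytotoxicity on these cells and only with the carboxylic acid side chain of compound 1 and compound 3 in place, so what the same change does on a compound lacking that chain is unknown.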